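The source may report more compounds than this note shows. Statements on the series, on what has been measured and on what is new or still open speak of the compounds shown alone.

Compound 3 `c1ccc(-c2ccns2)c(OCC2=NCCN2)c1` sits at the low end of the numbers seen so far: in a functional assay for activation of Alpha-1B adrenergic receptor (Homo sapiens), read by calcium flux (a lower number here means that less compound is needed, a higher number that more compound is needed for the effect), compound 3 gives 12.6 nM. Among the measured compounds shown here, compound 1 `c1cncc(-c2ccccc2OCC2=NCCN2)c1` gives 79.4 nM in this assay, and a 6.3-fold lower number from compound 1 to compound 3 (0.80 log units; beyond the scatter) is the only step with a readable size. Compound 2 `c1ccc(-c2ccncn2)c(OCC2=NCCN2)c1` gives only a limit in this assay, < 100000 nM. Because of the limit of < 100000 nM in this assay, at which 1 of the 3 values shown sits, the steps a step that the limit leaves unreadable from compound 1 to compound 2 and a step that the limit leaves unreadable from compound 2 to compound 3 have no readable size. Compound 4 `Cc1csc(-c2ccccc2OCC2=NCCN2)n1` differs from compound 3 by 4-methyl-1,3-thiazol-2-yl in place of 1,2-thiazol-5-yl on an aromatic carbon. For the measured compounds named here, no measured step covers this exchange of one five-membered ring for another; the limit on compound 2 shows that a ring swap of this kind can carry the number out of range, so the uncertainty is wide. A modest step is expected, a 2.4-fold higher number from compound 3 to compound 4 (0.38 log units; beyond the scatter), and compound 4 is estimated at 30 nM (range 8 nM to 150 nM).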

Compound 4, half-maximal effective concentration: < 100000 nM
Compound 4 ended at the assay's limit; the forecaster's own chance of this, stated with the estimate: 5%; the middle value lies beyond the limit too.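

Among the compounds shown here, compound 4 gives only a limit, so no step linking it to compound 1, compound 2 or compound 3 can be read: the limit of < 100000 nM in this assay, at which 2 of the 4 values shown sit.
Open, going by these compounds, is whether the methyl group or the 1,3-thiazol-2-yl ring itself separates compound 4 from compound 3.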